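The source may report more compounds than this note shows. Statements on the series, on what has been measured and on what is new or still open speak of the compounds shown alone.

Within the data shown here, compound 1 `C=CC(=O)Nc1cccc(Nc2ncnc(Nc3ccc(C(=O)N4CCCCC4)cc3)n2)c1` is the only compound here that carries a number: in a functional assay on Raji cells (Homo sapiens) for antiproliferative activity, read by CCK-8 assay, with a stated time of 24 h (on this read-out lower numbers stand for stronger inhibition and higher numbers for weaker inhibition), compound 1 gives 5140 nM. Compound 2 `C=CC(=O)Nc1cccc(Nc2nc(Cl)nc(Nc3ccc(OCCOC)cc3)n2)c1` shares much of the same core, but in this assay compound 2 gives "not determined" (no result reported), so it offers no comparison. Compound 3 `C=CC(=O)Nc1cccc(Nc2ncnc(Nc3ccc(C(=O)Nc4ccccn4)cc3)n2)c1` differs from compound 1 in one place: (pyridin-2-yl)amino in place of piperidin-1-yl on a carbonyl carbon. Among the measured compounds shown here, no measured pair shows what this change does, so only a modest step in this assay is expected, one that could fall either way and may not reach beyond the usual scatter. Compound 3 is estimated at 4000 nM, within a range from 1000 nM to 15000 nM, an expected step of a 1.3-fold lower number from compound 1 to compound 3 (0.11 log units; within the scatter).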

Compound 3, half-maximal inhibitory concentration: 15600 nM
Estimate against measurement, compound 3: 3.9-fold (0.59 log units) below; the measured number lies above the stated range.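

In this assay, the group on the carbonyl carbon clearly matters: putting (pyridin-2-yl)amino in place of piperidin-1-yl gives a 3.0-fold higher number from compound 1 to compound 3 (0.48 log units; beyond the scatter), a loss of inhibition. The swap exchanges a non-aromatic ring for an aromatic one and also adds a hydrogen-bond donor and acceptor, and this single pair cannot separate those differences. Nothing available here explains the loss. The compounds shown leave open how a phenylamino group, which has no ring nitrogen, or a small dimethylamino group would behave at this position.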